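Thiophene-core dihydroxyheptenoic acids: aryl for alkenyl

A few compounds are considered here, and "the series" means these few. Any claim that something is new, unique, unknown or untested is made for them only; others in the source may bear on it.

Measured compounds:
compound 1 `CC(C)=Cc1c(-c2ccccc2)sc(C(C)C)c1/C=C/[C@@H](O)C[C@@H](O)CC(=O)O` — 1000 nM
compound 2 `CC(C)c1sc(-c2ccccc2)c(C2CCCCC2)c1/C=C/[C@@H](O)C[C@@H](O)CC(=O)O` — 202 nM

In an assay on microsomes for inhibition of 3-hydroxy-3-methylglutaryl-coenzyme A reductase (Rattus norvegicus) (on this read-out higher numbers stand for weaker inhibition and lower numbers for stronger inhibition), compound 1 gives 1000 nM, the highest number of the two measured compounds; its nearest neighbour is compound 2, and the step of a 5.0-fold lower number from compound 1 to compound 2 (0.69 log units; beyond the scatter) is modest but beyond the scatter. Compound 3 `CC(C)c1sc(-c2ccccc2)c(-c2cccc(C(F)(F)F)c2)c1/C=C/[C@@H](O)C[C@@H](O)CC(=O)O` has not yet been measured in this assay. It differs from compound 1 by 3-(trifluoromethyl)phenyl in place of 2-methylprop-1-en-1-yl on an aromatic carbon. For the measured compounds named here, the only measured step that bears on this change is the one from compound 1 to compound 2, where a cyclohexyl group also took the place of the 2-methylprop-1-en-1-yl group and the number fell. A similar direction is therefore expected for compound 3, though the aromatic ring and the trifluoromethyl group leave the size uncertain. Compound 3 is estimated at 300 nM in this assay, within a range of 70 nM to 1300 nM, which would mean a step of a 3.3-fold lower number from compound 1 to compound 3 (0.52 log units; beyond the scatter).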

Compound 3, half-maximal inhibitory concentration: 2980 nM
Estimate against measurement, compound 3: 9.9-fold (1.00 log units) below; the whole stated range lies below it.
By their numbers in this assay, from the lowest: compound 2; then compound 1; then compound 3.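

In this assay, this position does not answer to every replacement of the 2-methylprop-1-en-1-yl group in the same direction. Cyclohexyl lowered the number, whereas 3-(trifluoromethyl)phenyl gives a 3.0-fold higher number from compound 1 to compound 3 (0.47 log units; beyond the scatter), so the earlier fall does not carry over to this group. The two ring-bearing groups are also far from interchangeable on this aromatic carbon, with a 15-fold higher number from compound 2 to compound 3 (1.17 log units; beyond the scatter), the largest step among the three compounds. Nothing shown accounts for this difference between the two groups. The compounds shown leave open whether the aromatic ring itself or the trifluoromethyl group on it goes with the higher number. An unsubstituted phenyl group at this position would separate the two, and a 4-fluorophenyl group would show whether another substituted aromatic ring behaves like 3-(trifluoromethyl)phenyl.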